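Chloro in place of hydrogen: compound 1 to compound 4

The source may hold more compounds than are shown below. What is called first, only, known or untested is meant among the compounds shown, and "the series" means these compounds.

Compound 1 `CC(C)c1onc(-c2c(Cl)cccc2Cl)c1COc1ccc(-c2nc3ccc(C(=O)O)cc3n2C)cc1` gives 7150 nM in an assay on HEK-293T cells for antagonist activity at vitamin D3 receptor (Homo sapiens), read by a luciferase reporter, with a stated time of 24 h (a lower number here means a stronger inhibitor, a higher number a weaker inhibitor), the highest of the three numbers in hand. Compound 2 `CCC(CC)n1c(-c2ccc(OCc3c(-c4c(Cl)cccc4Cl)noc3C(C)C)cc2)nc2ccc(C(=O)O)cc21`, with pentan-3-yl in place of methyl on an aromatic nitrogen, gives 5690 nM; a 1.3-fold lower number from compound 1 to compound 2 (0.10 log units; within the scatter). Compound 3 `CC(C)c1onc(-c2c(Cl)cccc2Cl)c1COc1ccc(-c2nc3ccc(C(=O)O)cc3n2C)c(Cl)c1`, carrying chloro in place of hydrogen on an aromatic carbon, gives 3520 nM; a 2.0-fold lower number from compound 1 to compound 3 (0.31 log units; beyond the scatter). Compound 4 `CC(C)c1onc(-c2c(Cl)cccc2Cl)c1COc1ccc(-c2nc3ccc(C(=O)O)cc3n2C)cc1Cl` differs from compound 1 by chloro in place of hydrogen on an aromatic carbon, placed on an aromatic carbon of a six-membered aromatic ring of carbon only, ortho to a large group and meta to a large group. Within the data shown here, only the step from compound 1 to compound 3 bears on this, and it was modest. A similar small lowering is therefore expected in this assay, so a 1.6-fold lower number from compound 1 to compound 4 (0.20 log units; within the scatter) is the estimated step. Compound 4 is expected at 4500 nM, within 2200 nM to 9000 nM.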

Compound 4, half-maximal inhibitory concentration: 2450 nM
The estimate for compound 4 lay 1.8-fold (0.26 log units) above the measured number; low and high end bracket the measured number.
By their numbers in this assay, from the lowest: compounds 4, 3, 2 and 1 (each within the scatter of the next, the first and the last beyond it).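

In this assay, chloro in place of hydrogen at this position, ortho to a large group and meta to a large group, gives a 2.9-fold lower number from compound 1 to compound 4 (0.47 log units; beyond the scatter), so a lowering beyond the scatter is now seen at a second aromatic carbon. Compound 3 (3520 nM) and compound 4 (2450 nM) lie within the scatter of each other, so these two chloro placements are not separated. No measurement in hand accounts for the lowering. Open, on these data alone, is whether bromo, methoxy or an amine at this position would follow chloro, and whether the chloro step holds with pentan-3-yl on the aromatic nitrogen, as in compound 2.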